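This account rests on a few compounds, and the source may have more. Where it says the series, first, only, none or still open, it means among the compounds named here.

Of the compounds shown here, three sharing one core have been measured in an ADME assay on MT4 cells (Homo sapiens) for cytotoxicity; a higher number here means that more compound is tolerated, a lower number that less compound is tolerated. Compound 1 `FC(F)(F)c1cccc(NC(=S)Nc2cccc(Br)c2)c1` gives 9200 nM. Compound 2 `FC(F)(F)c1cccc(NC(=S)Nc2ccc(Cl)cc2)c1` gives 6800 nM in this assay, and the step of a 1.4-fold lower number from compound 1 to compound 2 (0.13 log units; within the scatter) lies within the scatter. Compound 3 `FC(F)(F)c1cccc(NC(=S)NCc2ccco2)c1` gives 43000 nM in this assay, the highest of the three numbers; the steps of a 4.7-fold higher number from compound 1 to compound 3 (0.67 log units; beyond the scatter) and a 6.3-fold higher number from compound 2 to compound 3 (0.80 log units; beyond the scatter) both lie beyond the scatter and are modest in size.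

Compound 4 `CC(=O)NC(=S)Nc1cccc(C(F)(F)F)c1` has not yet been measured in this assay. It differs from compound 3 in one place: acetyl in place of (furan-2-yl)methyl on an amide-type nitrogen. For the measured compounds named here, no measured step involves the acetyl group, so none bears on this change directly. The two steps that lead to compound 3 only show that the (furan-2-yl)methyl group gave the highest number; whether a group with no ring moves the number further, or back toward compounds 1 and 2, cannot be read from them. The step of a 1.2-fold higher number from compound 3 to compound 4 (0.07 log units; within the scatter) is therefore expected to be small, with wide uncertainty in either direction. The estimate for compound 4 in this assay is 50000 nM, with a range from 15000 nM to 150000 nM.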

Compound 4, half-maximal cytotoxic concentration: > 100000 nM
Compound 4: a limit, no number; the forecaster's own chance of this, stated with the estimate: 25%; at least 2.0-fold (0.30 log units) between middle value and limit.
By their numbers in this assay, from the lowest: compounds 2 and 1 (each within the scatter of the next); then compound 3. At a limit, above all of these: compound 4.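

Compound 4 gives a limit and not a number in this assay: the limit of > 100000 nM in this assay, at which 1 of the 4 values shown sits.

On the amide-type nitrogen whose other neighbour is the thiocarbonyl carbon, acetyl in place of (furan-2-yl)methyl gives an at least 2.3-fold higher number from compound 3 to compound 4 (0.36 log units; beyond the scatter), so a group with no ring moves the number further up and not back toward compounds 1 and 2. The gap to the two phenyl-bearing compounds is larger, with an at least 10-fold higher number from compound 1 to compound 4 (1.03 log units; beyond the scatter) and an at least 14-fold higher number from compound 2 to compound 4 (1.16 log units; beyond the scatter), and among these four compounds each group with a ring carries a lower number than acetyl, the smallest group shown at this position.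

The compounds shown leave open how far compound 4 lies past its limit, and so the full size of all three steps remains unknown. Acetyl also differs from the other groups both in having no ring and in its carbonyl, so these two features cannot be told apart here; an ethyl group, with no ring and no carbonyl, and a benzoyl group, with both a ring and a carbonyl, would separate them.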